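The source may report more compounds than this note shows. Statements on the series, on what has been measured and on what is new or still open speak of the compounds shown alone.

Measured so far in a functional assay on HL-60 cells (Homo sapiens) for antiproliferative activity, read by MTT assay; a higher number here means a weaker inhibitor, a lower number a stronger inhibitor:
- compound 1 (`O[C@@H]1[C@@H](OCc2ccccc2)[C@H](OCc2ccccc2)[C@@H](COCc2ccccc2)O[C@@H]1c1ccccc1`), result ("not active" (no number reported))
- compound 2 (`CC(C)(C)C[C@H]1O[C@H](COCc2ccccc2)[C@@H](OCc2ccccc2)[C@H](OCc2ccccc2)[C@H]1O`), result (12100 nM)
- compound 3 (`CC(C)C[C@H]1O[C@H](COCc2ccccc2)[C@H](OCc2ccccc2)[C@H](OCc2ccccc2)[C@H]1O`), result ("not active" (no number reported))

Compound 3 has no number. Within the data shown here, its result matches that of compound 1, and compound 2 is the only compound here with a numerical value. The cut-off behind the not-active calls is not given, so the distance between compound 3 and compound 2 cannot be sized.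

The change to compound 4 (`CC(C)C[C@H]1O[C@H](COCc2ccccc2)[C@@H](OCc2ccccc2)[C@H](OCc2ccccc2)[C@H]1O`) is one of configuration only (the two compounds have the same atoms and bonds and differ only in configuration as drawn: 1 of 5 stereo elements differ; a stereocentre at a saturated ring carbon is drawn S in compound 3 and R in compound 4): the two compounds have the same atoms and bonds, and a stereocentre at a saturated ring carbon is drawn S in compound 3 and R in compound 4.

Among the measured compounds shown here, no measured step is available to size this change, and no measured pair of stereoisomers is available to calibrate it. In this assay the expected step is small, running from no reported activity towards, at best, a weak number. A second not-active result remains a real possibility. For the measured compounds named here, the only numerical anchor is compound 2 at (12100 nM), so any value for compound 4 is expected in that general region.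

Compound 4 is estimated at 20000 nM (expected range 8000 nM to 50000 nM).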

Compound 4, half-maximal inhibitory concentration: 13900 nM
Beside the measured number, compound 4's estimate is 1.4-fold (0.16 log units) above it; low and high end bracket the measured number.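

In this assay, among these compounds, compound 3 gives "not active" (no number reported) while compound 4 gives 13900 nM, so this pair is the first where a single stereocentre at a saturated ring carbon, drawn S in one and R in the other, accompanies the difference between no reported number and a measured one; without a number for compound 3, the size of that gap cannot be read. The difference in outcome can be assigned to configuration alone, because nothing else separates the two structures: the fact that compounds 3 and 4 differ only in the configuration as drawn. With the ring carbon drawn R, hydrogen in place of methyl on a saturated chain carbon bound to three saturated chain carbons gives a 1.1-fold higher number from compound 2 to compound 4 (0.06 log units; within the scatter), so this chain change leaves the result within the scatter.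

As far as these compounds go, it remains open whether the same change in configuration has a comparable outcome with the chain of compound 2, or at any of the other stereo elements of the shared core. Also open, from the compounds shown here alone, is how this assay responds to a longer chain or to an amine or carboxylic acid on that chain.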